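Allyloxy to benzyloxy on the shared core, compound 3 to compound 4

The compounds below may be only part of what the source reports. "The series", "measured", "known", "first", "only" and "open" are said of these compounds alone.

Compound 3, `C=CCONC(=O)CN1C(=O)S/C(=C\c2ccc(C(=O)N[C@H](C(=O)OC)C(C)C)cc2)C1=O`, carries an allyloxy group on its side chain and an isopropyl group on the saturated chain carbon bound to an amide-type nitrogen and a carbonyl carbon. In a functional assay on RAW264.7 cells (Mus musculus) for inhibition, read by microscopy and resazurin assay, with a stated time of 72 h (a lower number here means a stronger inhibitor, a higher number a weaker inhibitor), compound 3 reaches only the assay limit, > 128000 nM. Its two measured neighbours sit at the same limit. Compound 1, `C=CCONC(=O)CN1C(=O)S/C(=C\c2ccc(C(=O)N[C@@H](CC(C)C)C(=O)OC)cc2)C1=O`, gives > 128000 nM in this assay. Compound 2, `COC(=O)[C@H](CC(C)C)NC(=O)c1ccc(/C=C2\SC(=O)N(CC(=O)NOCc3ccccc3)C2=O)cc1`, gives > 128000 nM in this assay. The steps a step that the two limits leave unreadable from compound 1 to compound 3 and a step that the two limits leave unreadable from compound 1 to compound 2 are therefore unreadable, all three values resting at the limit of > 128000 nM in this assay, at which 3 of the 3 values shown sit.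

Compound 4, `COC(=O)[C@@H](NC(=O)c1ccc(/C=C2\SC(=O)N(CC(=O)NOCc3ccccc3)C2=O)cc1)C(C)C`, differs from compound 3 by phenyl in place of vinyl on a saturated chain carbon bound to an oxygen on an unsaturated carbon. Among the measured compounds shown here, the one measured step of the same change is a step that the two limits leave unreadable from compound 1 to compound 2, and it starts and ends at the limit of > 128000 nM in this assay, at which 3 of the 3 values shown sit, so neither direction nor size can be read from it. For compound 4 the expectation is accordingly a limit again rather than a number, estimated at 200000 nM with a range from 100000 nM to 500000 nM. The expected step that the limit leaves unreadable from compound 3 to compound 4 is thus taken as nothing beyond the scatter.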

Compound 4, half-maximal inhibitory concentration: > 128000 nM
Compound 4 ended at the assay's limit; the forecaster's own chance of this, stated with the estimate: 85%; the middle value is on the limit's open side.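

In this assay compound 4 gives > 128000 nM, a limit and not a number, so no step to it from compound 2 or compound 3 can be read: the limit of > 128000 nM in this assay, at which 4 of the 4 values shown sit.

The compounds shown leave open whether either change, allyloxy to benzyloxy or isobutyl to isopropyl, alters inhibition in this assay.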